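From 4-chlorophenyl to 3-methoxyphenyl: working notes on compound 3

This account rests on a few compounds, and the source may have more. Where it says the series, first, only, none or still open, it means among the compounds named here.

Among the measured compounds shown here, in a functional assay on PC-3 cells (Homo sapiens) for antiproliferative activity, read by CCK-8 assay, with a stated time of 72 h (a lower number here means a stronger inhibitor, a higher number a weaker inhibitor), compound 1 `Cc1cc(Nc2cc(N3CCN(C)CC3)nc(Nc3ccc(S(N)(=O)=O)cc3)n2)n[nH]1` gives 4380 nM and compound 2 `Cc1cc(Nc2cc(N3CCN(C)CC3)nc(Nc3ccc(Cl)cc3)n2)n[nH]1` gives 1480 nM, the lower of the two numbers so far. Compound 3 `COc1cccc(Nc2nc(Nc3cc(C)[nH]n3)cc(N3CCN(C)CC3)n2)c1` departs from compound 2 in one place, with 3-methoxyphenyl in place of 4-chlorophenyl on a nitrogen on an aromatic ring.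

For the measured compounds named here, the one measured step bearing on this is a 3.0-fold lower number from compound 1 to compound 2 (0.47 log units; beyond the scatter), a modest move beyond the scatter, with chloro in place of sulfamoyl on an aromatic carbon. Chloro leaves again here, so a step of similar or smaller size towards a higher number is expected in this assay. Going by the values given here, no measured compound carries 3-methoxyphenyl, so this guide is thin. The expected change is a 1.7-fold higher number from compound 2 to compound 3 (0.23 log units; within the scatter). For compound 3 the estimate is 2500 nM, with an expected range of 1000 nM to 6000 nM.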

Compound 3, half-maximal inhibitory concentration: 1080 nM
For compound 3 the middle estimate is 2.3-fold (0.36 log units) above the measured one; low and high end bracket the measured number.
By their numbers in this assay, from the lowest: compounds 3 and 2 (each within the scatter of the next); then compound 1.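

In this assay, the exchange on this nitrogen gives a 1.4-fold lower number from compound 2 to compound 3 (0.14 log units; within the scatter), so 4-chlorophenyl and 3-methoxyphenyl cannot be told apart here, even though the group and its printed ring number both change. The step of a 4.1-fold lower number from compound 1 to compound 3 (0.61 log units; beyond the scatter) lies beyond the scatter, so among the three compounds shown, compound 1, with its 4-sulfamoylphenyl, stands apart from both compound 2 and compound 3. No measurement of any property of these groups accompanies the result, and none bears on it.

Compound 3 alters the substituent and its printed ring number together, so the contribution of each remains unresolved. From the compounds shown here alone, it also remains open whether an amine or a carboxylic acid on this phenyl ring would fall with sulfamoyl or with chloro and methoxy.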